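Extending the amide substituent from methyl to ethyl

A few compounds are considered here, and "the series" means these few. Any claim that something is new, unique, unknown or untested is made for them only; others in the source may bear on it.

Measured so far:
compound 1, `NC(=O)CC[C@H](NS(=O)(=O)c1ccc([N+](=O)[O-])cc1)C(=O)O`, 7000 nM
compound 2, `CNC(=O)CC[C@H](NS(=O)(=O)c1ccc([N+](=O)[O-])cc1)C(=O)O`, 7500 nM

In an assay for inhibition of matrix metalloproteinase-9 (Homo sapiens), with stated times of 1 h, 1 min and 30 min (on this read-out lower numbers stand for stronger inhibition and higher numbers for weaker inhibition), compound 2 holds the highest of the two numbers; its nearest neighbour is compound 1, and the step of a 1.1-fold higher number from compound 1 to compound 2 (0.03 log units; within the scatter) lies within the scatter. Compound 3, `CCNC(=O)CC[C@H](NS(=O)(=O)c1ccc([N+](=O)[O-])cc1)C(=O)O`, differs from compound 2 by methyl in place of hydrogen on a saturated chain carbon bound to an amide-type nitrogen, read one bond further out as methylcarbamoyl to ethylcarbamoyl. Among the measured compounds shown here, only the step of a 1.1-fold higher number from compound 1 to compound 2 (0.03 log units; within the scatter) bears on this change, and it was flat. The expected step is therefore a 1.1-fold higher number from compound 2 to compound 3 (0.03 log units; within the scatter), no shift beyond the scatter. Compound 3 is expected near 8000 nM, with a range of 3000 nM to 20000 nM.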

Compound 3, half-maximal inhibitory concentration: 4800 nM
Beside the measured number, compound 3's estimate is 1.7-fold (0.22 log units) above it; the range from low to high includes it.
By their numbers in this assay, from the lowest: compounds 3, 1 and 2 (each within the scatter of the next).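

In this assay, methylcarbamoyl to ethylcarbamoyl gives a 1.6-fold lower number from compound 2 to compound 3 (0.19 log units; within the scatter), and the change from the unsubstituted amide gives a 1.5-fold lower number from compound 1 to compound 3 (0.16 log units; within the scatter). Ethyl, like methyl, therefore leaves the number within the scatter of the unsubstituted amide, so the flat picture at this position now covers all three compounds. Among the compounds shown here, no step in this short series yet reaches beyond the scatter.

On these data alone, whether a longer chain, an isopropyl group or a phenyl ring on this nitrogen would move the number beyond the scatter remains open. No measured evidence bears on these small steps.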